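Compound 3 to compound 4: methoxy for methyl

The source may report more compounds than this note shows. Statements on the series, on what has been measured and on what is new or still open speak of the compounds shown alone.

Measured in an ADME assay on 2209-23 cells (Homo sapiens) for cytotoxicity, read by WST assay (a lower number here means that less compound is tolerated, a higher number that more compound is tolerated), where each value is a limit of the assay:
Compound 1 `CS(=O)(=O)Nc1ccc2c(c1)S(=O)(=O)C=C(c1c(O)c3cc(F)ccc3n(Cc3ccc(F)c(F)c3)c1=O)N2`: > 50000 nM
Compound 2 `CS(=O)(=O)Nc1ccc2c(c1)S(=O)(=O)C=C(c1c(O)c3cc(F)ccc3n(Cc3cccnc3)c1=O)N2`: > 50000 nM
Compound 3 `CC(C)(C)CCn1c(=O)c(C2=CS(=O)(=O)c3cc(NS(C)(=O)=O)ccc3N2)c(O)c2cc(F)ccc21`: > 50000 nM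

Compound 3 gives no number on this scale. Its entry of > 50000 nM is a limit, and the whole series stands in the same place: the limit of > 50000 nM in this assay, at which 3 of the 3 values shown sit.

Compound 4 `COC(C)(C)CCn1c(=O)c(C2=CS(=O)(=O)c3cc(NS(C)(=O)=O)ccc3N2)c(O)c2cc(F)ccc21` keeps the shared core and changes one group. It carries methoxy in place of methyl on a saturated chain carbon bound to three saturated chain carbons, so that 3,3-dimethylbutyl becomes 3-methoxy-3-methylbutyl (methoxy in place of methyl on a saturated chain carbon bound to three saturated chain carbons).

For the measured compounds named here, the steps that bear on this change are those made on the same chain, and they fix no size. One is a step that the two limits leave unreadable from compound 2 to compound 3. The other is a step that the two limits leave unreadable from compound 1 to compound 3. Going by the values given here, the third, a step that the two limits leave unreadable from compound 1 to compound 2, is no more informative, so no measured step offers a size or a direction to carry over.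

Among the compounds with values here, the expectation therefore rests on compound 3, with its limit of > 50000 nM, and on the fact that no compound so far has left that limit. No step beyond the usual scatter is expected in this assay, and compound 4 will most likely be reported as a limit too. The expected step is a number no higher from compound 3 to compound 4 (the limit leaves the size open). The estimate for compound 4 is 50000 nM, with an expected range from 25000 nM to 100000 nM.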

Compound 4, half-maximal cytotoxic concentration: > 50000 nM
Compound 4: no number, only a limit; the forecaster's own chance of this, stated with the estimate: 85%; the middle value lies on the limit itself.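

In this assay, compound 4 gives only a limit, as do compounds 1, 2 and 3, and none of the steps from those three compounds to compound 4 can be read: the limit of > 50000 nM in this assay, at which 4 of the 4 values shown sit.

The compounds shown leave open how far any of the four lies from that limit, and whether methoxy in place of methyl changes the result at all.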